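A few compounds are considered here, and "the series" means these few. Any claim that something is new, unique, unknown or untested is made for them only; others in the source may bear on it.

Measured so far in a functional assay on CHO cells for inhibition of metabotropic glutamate receptor 5 (Rattus norvegicus), read by FLIPR and calcium flux; on this read-out lower numbers stand for stronger inhibition and higher numbers for weaker inhibition:
compound 1, `Cc1ccc2ccc(-c3cccc(C#N)c3)cc2n1`, gives 7.7 nM
compound 2, `Cc1ccc2ccc(-c3cccnc3)cc2n1`, gives 510 nM
compound 3, `COc1ccccc1-c1ccc2ccc(C)nc2c1`, gives 4200 nM

Compound 1 holds the lowest number of the three in this assay. The nearest to it is compound 2, whose 510 nM lies well beyond the scatter above compound 1; compound 3 is furthest away, its 4200 nM again far beyond the scatter. Among the measured compounds shown here, none of these three differs from another in a single place, so the numbers show only that compound 1 stands apart from both and that the two others are weaker, and nothing about what any single change does.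

Compound 4, `Cc1ccc2ccc(-c3cc(O)cc(C#N)c3)cc2n1`, is not yet measured. It differs from compound 1 in one place: hydroxy in place of hydrogen on an aromatic carbon. The hydroxy enters on an aromatic carbon of the six-membered aromatic ring of carbon only, meta to a cyano group and meta to a large group. For the measured compounds named here, no measured pair shows this change, so its size cannot be read from the series. The expectation is a modest step toward a higher number in this assay, roughly at the edge of the scatter, with compound 1 remaining the reference point. Compound 4 is expected to give about 25 nM, within 6 nM to 100 nM, which means an expected step of a 3.2-fold higher number from compound 1 to compound 4 (0.51 log units; beyond the scatter).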

Compound 4, half-maximal inhibitory concentration: 360 nM
Compound 4: middle estimate off by 14-fold (1.16 log units), on the low side; the whole stated range lies below it.
By their numbers in this assay, from the lowest: compound 1; then compounds 4 and 2 (each within the scatter of the next); then compound 3.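

Hydroxy in place of hydrogen on the aromatic carbon meta to a cyano group and meta to a large group gives a 47-fold higher number from compound 1 to compound 4 (1.67 log units; beyond the scatter) in this assay and is the first single-place step in the series. A single added heavy atom at this place is therefore enough to give up most of the inhibition seen for compound 1, so this carbon is not a free position for hydroxy. The earlier compounds set compound 1 apart from the others but tied no part of those gaps to one place, and no measurement on hand bears on why this step is so large.

Still open, going by these compounds, is whether the large step belongs to hydroxy itself or to any group entering on this carbon; methoxy, fluorine, an amine or a carboxylic acid at the same place would separate the two. Also open, on these data alone, is whether hydroxy on this carbon gives a step of similar size when the cyano group is replaced by another group, such as a primary amide or a chlorine atom.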